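The compounds below may be only part of what the source reports. "The series", "measured", "known", "first", "only" and "open" are said of these compounds alone.

Measured so far:
compound 1 `COc1ccc(/C=N/Nc2ncc3c(n2)n(C2CCCC2)c(=O)c(=O)n3C)c(OC)c1`; in a functional assay on PC-3 cells (Homo sapiens) for antiproliferative activity, read by MTT assay (on this read-out lower numbers stand for stronger inhibition and higher numbers for weaker inhibition), compound 1 gives > 100000 nM, which is a limit of the assay and not a number.
compound 2 `Cn1c(=O)c(=O)n(C2CCCC2)c2nc(N/N=C/c3cc([N+](=O)[O-])ccc3Cl)ncc21`; in this assay compound 2 gives 9260 nM.

Compound 2 therefore holds the only number shown; the other value sits at the limit of > 100000 nM in this assay, at which 1 of the 2 values shown sits. For the measured compounds named here, the single measured step, an at least 10-fold lower number from compound 1 to compound 2 (1.03 log units; beyond the scatter), came with 2-chloro-5-nitrophenyl in place of 2,4-dimethoxyphenyl on the carbon double-bonded to nitrogen, so the chloro and the nitro entered together in one move.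

Compound 3 `Cn1c(=O)c(=O)n(C2CCCC2)c2nc(N/N=C/c3ccccc3Cl)ncc21` keeps the chloro and drops the nitro: hydrogen in place of nitro on an aromatic carbon. Going by the values given here, no measured step removes a nitro on its own; the only step that bears on it is the one above, in which both groups arrived as the number fell beyond the scatter. Taking one of those two groups away again is expected to hand back part of that gain, a moderate rise in the number, a 2.7-fold higher number from compound 2 to compound 3 (0.43 log units; beyond the scatter). Compound 3 is estimated at 25000 nM, within 8000 nM to 90000 nM.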

Compound 3, half-maximal inhibitory concentration: 16300 nM
Compound 3: the middle estimate sits 1.5-fold (0.19 log units) above what was measured; low and high end bracket the measured number.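

In this assay, the aromatic carbon para to the chloro group accepts hydrogen in place of nitro with no change that can be read: the swap gives a 1.8-fold higher number from compound 2 to compound 3 (0.25 log units; within the scatter). The nitro is therefore not needed to hold this level, and 2-chlorophenyl without it still gives an at least 6.1-fold lower number from compound 1 to compound 3 (0.78 log units; beyond the scatter). This step is bounded on one side, since compound 1 stands at a limit and not at a number: the limit of > 100000 nM in this assay, at which 1 of the 3 values shown sits.

The compounds shown do not separate the entry of the chloro from the loss of 2,4-dimethoxyphenyl, so what carries the gain over compound 1 stays open. Going by these compounds, how an amine, a carboxylic acid or a methyl group would read in place of the nitro, or hydrogen in place of the chloro, also stays open.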